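Swapping pyrazine for imidazole on the shared core

A few compounds are considered here, and "the series" means these few. Any claim that something is new, unique, unknown or untested is made for them only; others in the source may bear on it.

Compound 3 `c1ccc(-c2cnccn2)c(OCC2=NCCN2)c1` is one of three close relatives tested in a functional assay for activation of Alpha-1D adrenergic receptor (Homo sapiens), read by calcium flux; on this read-out lower numbers stand for an effect already at smaller amounts and higher numbers for an effect only at larger amounts of compound. In this assay compound 3 gives < 100000 nM, which is a limit of the assay rather than a number. Compound 1 `Cc1cccnc1-c1ccccc1OCC1=NCCN1` gives < 100000 nM, likewise a limit. Compound 2 `c1cnc(-c2ccccc2OCC2=NCCN2)nc1` gives < 100000 nM, also a limit. Because (the limit of < 100000 nM in this assay, at which 3 of the 3 values shown sit), no step among these compounds can be read; the single one-point change, a step that the two limits leave unreadable from compound 2 to compound 3, stays unreadable. Compound 4 `c1ccc(-c2ncc[nH]2)c(OCC2=NCCN2)c1` differs from compound 3 by 1H-imidazol-2-yl in place of pyrazin-2-yl on an aromatic carbon. Going by the values given here, no measured step bears on this change, so no size or direction can be drawn from the numbers; an estimate can only follow the shared limit. Compound 4 is therefore expected to give 3000 nM, within 300 nM to 30000 nM, an expected step that the limit leaves unreadable from compound 3 to compound 4.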

Compound 4, half-maximal effective concentration: < 100000 nM
Compound 4 gave a limit, no number; the forecaster's own chance of this, stated with the estimate: 40%; the middle value is on the limit's open side.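

No step to compound 4, whether from compound 2 or from compound 3, can be read, because every compound shown gives a limit rather than a number: the limit of < 100000 nM in this assay, at which 4 of the 4 values shown sit.

The compounds shown leave open how far swapping the ring on the shared core changes the result in this assay.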